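Swapping a methylphenyl for a nitrophenyl: cytotoxicity outlook

The source may report more compounds than this note shows. Statements on the series, on what has been measured and on what is new or still open speak of the compounds shown alone.

Measured so far:
compound 1 `c1ccc(-c2ccc(Cn3cncc3CNc3cccc(-c4ccccc4)c3)cc2)cc1` — 10000 nM
compound 2 `COC(=O)c1ccc(NCc2cncn2Cc2cccc(C)c2)cc1-c1ccccc1` — > 10000 nM
compound 3 `Fc1ccc(Cn2cncc2CNc2ccc(-c3nc4ccccc4s3)c(-c3ccccc3)c2)c(F)c1` — > 1000 nM

All three compounds were tested in a toxicity assay on NIH3T3 cells (Mus musculus) for cytotoxicity, read by resazurin assay; a lower number here means that less compound is needed, a higher number that more compound is needed for the effect. Compound 1 gives 10000 nM. Compound 2 reaches only a limit of this assay, reported as > 10000 nM. Compound 3 likewise reaches only a limit, reported as > 1000 nM. Two of the three results are therefore limits rather than numbers: compound 2 sits at the limit of > 10000 nM in this assay, at which 1 of the 3 values shown sits, and compound 3 sits at the limit of > 1000 nM in this assay, at which 1 of the 3 values shown sits. Compound 2 thus stands at the weakest end of what this assay can resolve, with no number to compare against compound 1 beyond the fact that no cytotoxic effect was reached within the tested range.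

The next compound, compound 4 `COC(=O)c1ccc(NCc2cncn2Cc2ccccc2[N+](=O)[O-])cc1-c1ccccc1`, keeps the core of compound 2 and differs in one group: 2-nitrophenyl in place of 3-methylphenyl on a saturated chain carbon bound to an aromatic nitrogen. Going by the values given here, no pair of measured compounds differs in a single place, so there is no measured step to lean on. The expectation is a step of no size beyond the scatter, with compound 4 remaining out of reach of this assay much as compound 2 is.

Compound 4 is therefore expected to give 15000 nM in this assay, within a range from 5000 nM to 50000 nM. The expected step is a step that the limit leaves unreadable from compound 2 to compound 4, most likely reported again as a limit.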

Compound 4, half-maximal effective concentration: 10000 nM
For compound 4 the middle estimate is 1.5-fold (0.18 log units) above the measured one; the range from low to high includes it.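

In this assay compound 4 gives an actual number, 10000 nM, so with 2-nitrophenyl on this saturated chain carbon bound to an aromatic nitrogen, the result falls within what the assay can express as a number, which was not the case for compound 2 with 3-methylphenyl. Swapping these two groups therefore reads as a number no higher from compound 2 to compound 4 (the limit leaves the size open), and it is the only step shown at this place. Its size cannot be read, and no claim of a large or small change can be made, because the result for compound 2 is a limit and not a number: the limit of > 10000 nM in this assay, at which 1 of the 4 values shown sits.

The swap removes a methyl group and brings in a nitro group at a different place on the ring, so these two compounds cannot show which of those differences matters for the result. Nor can they show how this place responds to other groups, such as a phenyl ring carrying an amine or a carboxylic acid, or a longer chain between the ring and the aromatic nitrogen.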